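Nitro in place of formyl on the aryl ring

The source may hold more compounds than are shown below. What is called first, only, known or untested is meant among the compounds shown, and "the series" means these compounds.

Three compounds of the series have numbers in a functional assay (Homo sapiens); a higher number here means a weaker inhibitor, a lower number a stronger inhibitor. Compound 1 `Nc1nc2ccnc(-c3cc[n+]([O-])cc3)n2n1` gives 5600 nM in this assay. Compound 2 `Nc1nc2ccnc(-c3cccc(C=O)c3)n2n1` gives 700 nM in this assay. Compound 3 `Cc1ccc(S(=O)(=O)Nc2cccc(-c3nccc4nc(N)nn34)c2)cc1` gives 1500 nM in this assay. Among these three numbers compound 2 stands lowest: compound 3 is its nearest, a gap beyond the scatter, and compound 1 its furthest, a gap also beyond the scatter. The three compounds share one core and differ only in the group carried on it.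

Compound 4 `Nc1nc2ccnc(-c3cccc([N+](=O)[O-])c3)n2n1` has not yet been measured in this assay. Against compound 2 it differs in one place: nitro in place of formyl on an aromatic carbon. For the measured compounds named here, no pair of measured compounds shows this change, so no measured step can be read across to it; the expectation rests on the three numbers above and on the nature of the change alone. With a formyl leaving and a nitro entering on the same aromatic carbon, the step of a 1.3-fold higher number from compound 2 to compound 4 (0.11 log units; within the scatter) is expected to be small, lying within the scatter or only just beyond it, with no clear direction. Compound 4 is therefore estimated at 900 nM, with a range from 300 nM to 2700 nM.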

Compound 4, half-maximal inhibitory concentration: 3800 nM
For compound 4 the middle estimate is 4.2-fold (0.63 log units) below the measured one; the whole stated range lies below it.
By their numbers in this assay, from the lowest: compound 2; then compound 3; then compounds 4 and 1 (each within the scatter of the next).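

In this assay, for the compounds shown here, nitro in place of formyl on this aromatic carbon, meta to a large group, gives a 5.4-fold higher number from compound 2 to compound 4 (0.73 log units; beyond the scatter), the first step that isolates a change in one place. The position therefore distinguishes these two groups, even though each has one double bond outside aromatic rings, no hydrogen-bond donors and no net charge, and the formyl of compound 2 keeps the lowest number among the four compounds. No measurement at hand bears on the cause of this step, which stays unassigned.

The compounds shown leave open whether the step reflects something particular to nitro or the loss of something particular to formyl, a question that a nitrile, a carboxylic acid or an amine on the same aromatic carbon would help to separate. They also leave open whether the same exchange would give a step of similar size on another carbon of the ring, or with a different large group on the shared core.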